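A few compounds are considered here, and "the series" means these few. Any claim that something is new, unique, unknown or untested is made for them only; others in the source may bear on it.

Measured so far in a physicochemical assay for solubility, with a stated time of 18 h, at pH 7.4; on this read-out lower numbers stand for lower solubility and higher numbers for higher solubility:
compound 1 `COc1cccc(CNCCCNc2ccnc3cc(C4CCCCC4)ccc23)c1O` — 4200 nM
compound 2 `COc1ccc(F)cc1CNCCCNc1ccnc2cc(C3CCCCC3)ccc12` — 4200 nM
compound 3 `COc1ccc(-c2ccc3c(NCCCNCc4ccco4)ccnc3c2)cc1` — 32000 nM

Compound 2 stands level with compound 1 in this assay, the two within the scatter of each other, while compound 3 gives a markedly higher number, beyond the scatter. For the measured compounds named here, the one single-point step measured, no change at the digits printed from compound 1 to compound 2 (within the scatter), concerns the benzylic aryl group on the amine side of the molecule and not the position that changes here.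

Compound 4 `COc1ccc(F)cc1CNCCCNc1ccnc2cc(Oc3ccccc3)ccc12` differs from compound 2 as follows: phenoxy in place of cyclohexyl on an aromatic carbon. Going by the values given here, no measured step alters this position alone; compound 3 carries an aromatic group at the same place but also a different amine-side group, so its higher value cannot be assigned to the ring change by itself. The expectation is therefore a modest rise, uncertain in size, with a 1.9-fold higher number from compound 2 to compound 4 (0.28 log units; within the scatter) as the expected step. Compound 4 is estimated at 8000 nM in this assay, within a range from 3000 nM to 25000 nM.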

Compound 4, solubility: 14500 nM
The estimate for compound 4 lay 1.8-fold (0.26 log units) below the measured number; the range from low to high includes it.
By their numbers in this assay, from the lowest: compounds 1 and 2 (each within the scatter of the next); then compound 4; then compound 3.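

In this assay, for the compounds shown here, phenoxy in place of cyclohexyl on the aromatic carbon of the shared core gives a 3.5-fold higher number from compound 2 to compound 4 (0.54 log units; beyond the scatter) and is the first reading of this position with everything else held constant. Going by these compounds alone, the number at this position therefore moves beyond the scatter, whereas the one earlier single-point change, on the aryl group of the amine side, gave no change at the digits printed from compound 1 to compound 2 (within the scatter) and stayed within it. Nothing available gives a reason for this rise.

Open, going by these compounds, is what a cyclohexyloxy group or a directly bound phenyl would give at this place, so the share of the oxygen and that of the aromatic ring in the step cannot yet be told apart. Also open, on these data alone, are the effect of a morpholine or a carboxylic acid on the phenoxy ring and whether the step holds with another amine-side group.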